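Permeability of amine substituents on a shared core

This account rests on a few compounds, and the source may have more. Where it says the series, first, only, none or still open, it means among the compounds named here.

Measured compounds in an ADME assay for permeability, using PAMPA, at pH 7.4; on this read-out higher numbers stand for higher permeability and lower numbers for lower permeability:
compound 1 `CCCN(C[C@H]1Cc2c(cccc2N2CCNCC2)CN1)[C@H]1CCCc2cccnc21` gives 26.5 nm/s
compound 2 `c1cnc2c(c1)CCC[C@@H]2N(CC1CCCCC1)C[C@H]1Cc2c(cccc2N2CCNCC2)CN1` gives 9 nm/s

For the measured compounds named here, compound 2 has the lower of the two numbers in this assay; the only step available is a 2.9-fold lower number from compound 1 to compound 2 (0.47 log units; beyond the scatter). Compound 3 `CC(C)N(C[C@H]1Cc2c(cccc2N2CCNCC2)CN1)[C@H]1CCCc2cccnc21` differs from compound 2 by isopropyl in place of cyclohexylmethyl on an amine nitrogen. This change runs opposite to that step in ring content, so compound 3 is expected to move back upward in this assay by a step of about that size, near compound 1's level 26.5 nm/s. Compound 3 is therefore estimated at 24 nm/s in this assay, within 12 nm/s to 48 nm/s, a step of a 2.7-fold higher number from compound 2 to compound 3 (0.43 log units; beyond the scatter).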

Compound 3, apparent permeability: 16 nm/s
Compound 3: middle estimate off by 1.5-fold (0.18 log units), on the high side; measured number inside the range.
By their numbers in this assay, from the lowest: compounds 2, 3 and 1 (each within the scatter of the next, the first and the last beyond it).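

In this assay, isopropyl in place of cyclohexylmethyl on the amine nitrogen gives a 1.8-fold higher number from compound 2 to compound 3 (0.25 log units; within the scatter), while isopropyl in place of propyl gives a 1.7-fold lower number from compound 1 to compound 3 (0.22 log units; within the scatter). Isopropyl thus cannot be told apart from either group at this position, although the earlier step, a 2.9-fold lower number from compound 1 to compound 2 (0.47 log units; beyond the scatter), lies beyond the scatter. Nothing available explains these steps. The compounds shown leave open how a benzyl group, a longer chain or a chain carrying a carboxylic acid on this nitrogen would read in this assay.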